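Oxazolyl ketone series: formyl to methylsulfanyl step

A few compounds are considered here, and "the series" means these few. Any claim that something is new, unique, unknown or untested is made for them only; others in the source may bear on it.

Compound 1 `O=C(CCCCCc1ccccc1)c1nc2cccc(Br)c2o1`: in an assay on HEK-293T cells for inhibition of diacylglycerol lipase-alpha (Homo sapiens), read by colorimetric assay (on this read-out lower numbers stand for stronger inhibition and higher numbers for weaker inhibition), compound 1 gives > 10000 nM, which is a limit of the assay and not a number.
Compound 2 `O=Cc1coc(C(=O)CCCCCCc2ccccc2)n1`: in this assay compound 2 gives 1510 nM.

Compound 2 stands as the only number shown in this assay; the one further value, that of compound 1, is a limit (the limit of > 10000 nM in this assay, at which 1 of the 2 values shown sits). Going by the values given here, no step between measured compounds is available, so nothing in the measured set tells how much a change on the oxazole moves the read-out.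

Compound 3 `CSc1cnc(C(=O)CCCCCCc2ccccc2)o1` is not yet measured in this assay. It differs from compound 2 as follows: 5-(methylsulfanyl)-1,3-oxazol-2-yl in place of 4-formyl-1,3-oxazol-2-yl on a carbonyl carbon

The step from compound 2 to compound 3 is expected to be a 2.6-fold higher number from compound 2 to compound 3 (0.42 log units; beyond the scatter), going towards weaker inhibition and beyond the usual scatter. Compound 3 is estimated at 4000 nM, with a range from 800 nM to 20000 nM.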

Compound 3, half-maximal inhibitory concentration: > 10000 nM
Compound 3 gave a limit, no number (the forecaster's own chance of this, stated with the estimate: 30%); middle value at least 2.5-fold (0.39 log units) from the limit.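

In this assay, going by these compounds alone, the first readable change on the oxazole, 5-(methylsulfanyl)-1,3-oxazol-2-yl in place of 4-formyl-1,3-oxazol-2-yl on a carbonyl carbon, gives an at least 6.6-fold higher number from compound 2 to compound 3 (0.82 log units; beyond the scatter), towards weaker inhibition. Compound 3 gives > 10000 nM, which is a limit of the assay and not a number, and the true size of the step stays unknown for that reason: the limit of > 10000 nM in this assay, at which 2 of the 3 values shown sit. The two groups match in heavy atoms and hydrogen-bond acceptors, yet the read-out still moves beyond the scatter, and those counts alone do not account for the step.

This single step swaps the group and its place on the oxazole together, and the two changes cannot be read apart. Open, from the compounds shown here alone, is how 4-(methylsulfanyl)-1,3-oxazol-2-yl, 5-formyl-1,3-oxazol-2-yl or a carboxylic acid on the oxazole would read.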